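This account rests on a few compounds, and the source may have more. Where it says the series, first, only, none or still open, it means among the compounds named here.

Measured compounds:
compound 1 `Nc1scc(-c2cccc(F)c2)c1C(=O)c1ccccc1`: 51%
compound 2 `Nc1scc(-c2ccc3ccccc3c2)c1C(=O)c1ccccc1`: 55%
compound 3 `Nc1scc(-c2cccc(F)c2)c1C(=O)c1ccc(Cl)cc1`: 76%

In a functional assay on CHO cells for agonist activity at adenosine receptor A1 (Homo sapiens), read by fluorescence and ERK phosphorylation, with stated times of 30 min and 1.5 h, tested at 3 uM (on this read-out higher numbers stand for a stronger effect at the one concentration tested and lower numbers for a weaker effect), compound 3 stands highest of the three, with compound 2 nearest and compound 1 furthest, both gaps beyond the scatter. Going by the values given here, the one step that changes a single place, a number 25 percentage points higher from compound 1 to compound 3 (beyond the scatter), comes from a chloro in place of hydrogen on an aromatic carbon of the other ring and is modest. Compound 1 and compound 2 differ in the whole aryl group and their values lie within the scatter of each other.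

The next compound, compound 4 `Nc1scc(-c2cccc(Br)c2)c1C(=O)c1ccc(Cl)cc1`, differs from compound 3 only by bromo in place of fluoro on an aromatic carbon. Among the compounds with values here, no measured step exchanges one halogen for another on this ring, so nothing speaks for a shift in either direction; the swap of one heavy atom for one heavy atom with no ring, donor or acceptor change is taken as roughly neutral. The expected step of a number 2 percentage points lower from compound 3 to compound 4 (within the scatter) is therefore none beyond the scatter. For compound 4 the estimate in this assay is 74%, within 58% to 88%.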

Compound 4, a percentage reported as activity, at one concentration (the size of the read-out at that concentration, not a potency): 62%
The estimate for compound 4 lay 12 percentage points above the measured number; measured number inside the range.
By their numbers in this assay, from the lowest: compounds 1, 2 and 4 (each within the scatter of the next, the first and the last beyond it); then compound 3.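

In this assay, the change from 3-fluorophenyl to 3-bromophenyl gives a number 14 percentage points lower from compound 3 to compound 4 (beyond the scatter) and shows that the read-out is sensitive to which halogen sits at this position. Going by these compounds alone, this is the first single-place step on this ring, and it runs in the opposite direction to the step from adding chloro on the other ring, a number 25 percentage points higher from compound 1 to compound 3 (beyond the scatter) in the earlier data. No measured evidence bears on what lies behind the drop. On these data alone, with only fluoro and bromo compared here, it remains open how chloro, a methoxy group, an amine or plain hydrogen at this place would read. Also open, as far as these compounds go, is whether the same halogen exchange gives a similar step without the chloro on the other ring.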